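Dropping a fluorine from the benzyl group of a reductase inhibitor

The source may report more compounds than this note shows. Statements on the series, on what has been measured and on what is new or still open speak of the compounds shown alone.

Compound 1 `O=C(O)C[C@H](O)C[C@H](O)CCn1c(-c2ccc(F)cc2)nc(C(=O)NCc2ccc(F)cc2)c1C1CC1` is the stronger of two measured compounds in an assay on microsomes from liver for inhibition of 3-hydroxy-3-methylglutaryl-coenzyme A reductase (Rattus norvegicus), read by scintillation counting, with stated times of 0.5 h and 0.75 h (a higher number here means a weaker inhibitor, a lower number a stronger inhibitor), where compound 1 gives 3.4 nM. Compound 2 `COc1ccccc1CNC(=O)c1nc(-c2ccc(F)cc2)n(CC[C@@H](O)C[C@@H](O)CC(=O)O)c1C1CC1` differs from it in one place and in this assay compound 2 gives 7 nM; that step, 2-methoxyphenyl in place of 4-fluorophenyl on a saturated chain carbon bound to an amide-type nitrogen, is a 2.1-fold higher number from compound 1 to compound 2 (0.31 log units; beyond the scatter).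

Compound 3 `O=C(O)C[C@H](O)C[C@H](O)CCn1c(-c2ccc(F)cc2)nc(C(=O)NCc2ccccc2)c1C1CC1` is not yet measured. It differs from compound 1 by hydrogen in place of fluoro on an aromatic carbon. Among the compounds with values here, the only step that touches this part of the molecule is the one from compound 1 to compound 2, which changed the same aromatic ring more thoroughly and still moved the number only modestly. A smaller change should do no more, so the expected step is a 1.5-fold higher number from compound 1 to compound 3 (0.17 log units; within the scatter), a slight weakening or none beyond the scatter. Compound 3 is therefore estimated at 5 nM in this assay, within 2 nM to 12 nM.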

Compound 3, half-maximal inhibitory concentration: 1.4 nM
Beside the measured number, compound 3's estimate is 3.6-fold (0.55 log units) above it; measured number below the stated range.
By their numbers in this assay, from the lowest: compound 3; then compound 1; then compound 2.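

In this assay, taking the fluorine off the benzyl group strengthens the inhibitor rather than weakening it, with a 2.4-fold lower number from compound 1 to compound 3 (0.39 log units; beyond the scatter), so the fluoro group is not needed at this place for strong inhibition. The plain benzyl group also beats the methoxy-bearing one, with a 5.0-fold lower number from compound 2 to compound 3 (0.70 log units; beyond the scatter), and among these three compounds both ring substituents go with a higher number than hydrogen, with no compound going against this. Nothing available explains why hydrogen does better here than fluoro or methoxy.

From the compounds shown here alone, the two substituents sit at different places on the ring, so it stays open whether the 2-methoxyphenyl result reflects the methoxy group itself or where it sits. Also open, going by these compounds, is how a chloro, methyl or amino group para to the large group would compare with hydrogen, and whether a longer chain between the amide nitrogen and the phenyl ring would keep this strength.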